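The compounds below may be only part of what the source reports. "The series", "measured", "known", "first", "only" and "open" are said of these compounds alone.

Three compounds have values in an ADME assay on L6 cells (Rattus norvegicus) for cytotoxicity, read by resazurin assay, with a stated time of 72 h (a lower number here means a stronger inhibitor, a higher number a weaker inhibitor), so far:

Compound 1 `CN1CCN(CCC(=O)N2CC3C(c4ccccc4)CC(N(C)C)(CC3c3ccccc3)C2)CC1` gives 13000 nM
Compound 2 `CN(C)C12CC(c3ccccc3)C(CN(CCCN3CCCC3)C1)C(c1ccccc1)C2` gives 1550 nM
Compound 3 `CN(C)C12CC(c3ccccc3)C(CN(CCCN3CCCCC3)C1)C(c1ccccc1)C2` gives 1750 nM

Compound 3 stands at 1750 nM on this small scale. The gap to its nearest neighbour is a 1.1-fold higher number from compound 2 to compound 3 (0.05 log units; within the scatter) and so gives no order between the two. The compound carrying (2-(4-methylpiperazin-1-yl)ethyl)carbonyl lies well apart, with a 7.4-fold lower number from compound 1 to compound 3 (0.87 log units; beyond the scatter) and also an 8.4-fold lower number from compound 1 to compound 2 (0.92 log units; beyond the scatter) in the same direction.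

The next compound is compound 4 `CCN(CC)CCCN1CC2C(c3ccccc3)CC(N(C)C)(CC2c2ccccc2)C1` and its change from compound 3 falls at the end of the 3-(piperidin-1-yl)propyl chain: diethylamino in place of piperidin-1-yl on a saturated chain carbon, three bonds along the chain from an amine nitrogen in a ring.

The pyrrolidin-1-yl to piperidin-1-yl exchange at this same place bears most directly on the change, and it stayed within the scatter. The two larger steps replace the whole group on the amine nitrogen in a ring, so they say little about this exchange. For the measured compounds named here, no compound with a diethylamino group has been measured, and the reading rests on that single comparison. No step beyond the scatter is therefore expected in this assay for this change.

The expected size of the change is a 1.0-fold lower number from compound 3 to compound 4 (0.01 log units; within the scatter) as estimated here.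

Compound 4 is estimated at 1700 nM with an expected range from 850 nM to 3400 nM in this read-out.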

Compound 4, half-maximal inhibitory concentration: 3270 nM
Compound 4: the middle estimate sits 1.9-fold (0.28 log units) below what was measured; the measured number falls inside the stated range.
By their numbers in this assay, from the lowest: compounds 2, 3 and 4 (each within the scatter of the next, the first and the last beyond it); then compound 1.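

In this assay, for the compounds shown here, replacing the ring of piperidin-1-yl with the open diethylamino group at the end of the propyl chain gives no step that can be separated from the scatter (a 1.9-fold higher number from compound 3 to compound 4 (0.27 log units; within the scatter)). Diethylamino in place of pyrrolidin-1-yl at the same place does pass the scatter, though only modestly (a 2.1-fold higher number from compound 2 to compound 4 (0.32 log units; beyond the scatter)), so this is the first exchange of the end group to do so, while compound 3 stays within the scatter of both compound 2 and compound 4. The open-chain end group also leaves the propyl compounds on the same side of compound 1 (a 4.0-fold lower number from compound 1 to compound 4 (0.60 log units; beyond the scatter)), so all three end groups on the propyl chain now give numbers beyond the scatter from that compound.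

No measurement shown gives a reason for these differences. The compounds leave open whether a morpholin-4-yl or dimethylamino end group, or a longer chain, would stay in this narrow band, and whether the step from compound 1 follows from its carbonyl or from its 4-methylpiperazin-1-yl group, since the two change together.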